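Hydroxyphenyl pyridine series: shifting the hydroxyl

A few compounds are considered here, and "the series" means these few. Any claim that something is new, unique, unknown or untested is made for them only; others in the source may bear on it.

Measured compounds in an assay on isolated protein for inhibition of DNA topoisomerase 1 (Homo sapiens), with a stated time of 30 min, tested at 100 uM; a higher number here means a stronger effect of the compound at the concentration tested, a lower number a weaker effect:
compound 1 `Oc1ccc(-c2cc(-c3cccnc3)nc(-c3ccccc3Cl)c2)cc1` — compound 1 gives 0.9%
compound 2 `Oc1ccc(-c2cc(-c3cccc(Cl)c3)nc(-c3ccccn3)c2)cc1` — compound 2 gives 59.4%
compound 3 `Oc1ccc(-c2cc(-c3ccsc3)nc(-c3cccc(Cl)c3)c2)cc1` — compound 3 gives 26%

Compound 2 stands highest of the three numbers in this assay; compound 3 is nearest and compound 1 furthest, both beyond the scatter. Among the measured compounds shown here, the only single-place step measured so far is a number 33.4 percentage points lower from compound 2 to compound 3 (beyond the scatter), and it concerns a different substituent of the shared core than the one changed here. Compound 1 and compound 2 differ in more than one place, so their two values alone show that compound 1 sits far lower.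

Compound 4 `Oc1cccc(-c2cc(-c3cccc(Cl)c3)nc(-c3ccccn3)c2)c1` is not yet measured. It differs from compound 2 as follows: 3-hydroxyphenyl in place of 4-hydroxyphenyl on an aromatic carbon. For the measured compounds named here, no measured step bears on this change, since the 4-hydroxyphenyl group is kept in all three measured compounds. The expectation therefore rests on compound 2 alone, and the step is expected to be a number 14.4 percentage points lower from compound 2 to compound 4 (beyond the scatter), with a wide range. For compound 4 in this assay the estimate is 45%, between 15% and 75%.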

Compound 4, a percentage reported as inhibition, at one concentration (the size of the read-out at that concentration, not a potency): 0.4%
The estimate for compound 4 lay 44.6 percentage points above the measured number; measured number outside the range, below it.
By their numbers in this assay, from the lowest: compounds 4 and 1 (each within the scatter of the next); then compound 3; then compound 2.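

In this assay, the step at this position is a number 59 percentage points lower from compound 2 to compound 4 (beyond the scatter), with 3-hydroxyphenyl in place of 4-hydroxyphenyl. Among the compounds shown here, the two groups have the same atoms and the same hydrogen-bond donor and acceptor counts, so at this place, opposite the ring nitrogen, the read-out depends strongly on where the hydroxyl sits on the phenyl ring, which the earlier compounds, all carrying 4-hydroxyphenyl, could not show. The data at hand give no reason for the size of this step.

Going by these compounds, whether an amine or a methoxy group in place of the hydroxyl of compound 2 would keep the read-out remains open. Also open, on these data alone, is whether 3-hydroxyphenyl would bring a step of similar size with the thiophen-3-yl group of compound 3 on the shared core.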